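This account rests on a few compounds, and the source may have more. Where it says the series, first, only, none or still open, it means among the compounds named here.

In a functional assay on the whole organism (strain Wistar) for inhibition, with Rattus norvegicus as the target, with stated times of 30 min and 2 h, at a dose of 20 mg/kg by the oral route (on this read-out higher numbers stand for more inhibition at the one dose given (going by the name of the read-out) and lower numbers for less inhibition), three analogues sharing one core have been measured. Compound 1, `Cc1ccc(C(=O)CCc2nnc(-c3ccc(Cl)cc3)o2)cc1`, gives 62.7%. Compound 2, `Cc1ccc(C(=O)CCc2nnc(-c3ccc([N+](=O)[O-])cc3)o2)cc1`, gives 52%. Compound 3, `COc1ccc(-c2nnc(CCC(=O)c3ccc(C)cc3)o2)cc1`, gives 69.3%. Among these, a number 10.7 percentage points lower from compound 1 to compound 2 (beyond the scatter), whereas a number 6.6 percentage points higher from compound 1 to compound 3 (within the scatter), and a number 17.3 percentage points higher from compound 2 to compound 3 (beyond the scatter). Compound 3 therefore holds the highest of the three numbers, though its gap to compound 1 is within the scatter, so only its separation from compound 2 counts as a real difference.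

The next compound, compound 4, `COc1ccc(-c2nnc(CCC(=O)c3ccc(C)cc3)o2)cc1OC`, has not yet been measured in this assay. It differs from compound 3 in one place: methoxy in place of hydrogen on an aromatic carbon. Within the data shown here, none of the measured steps concerns a methoxy taking the place of a hydrogen; each of them exchanges one group for another on the same aromatic carbon. What the measured steps do show is that the whole series, with chloro, nitro or methoxy at that position, stays within a fairly narrow band. On that basis compound 4 is expected to give a number close to that of compound 3, with no step beyond the scatter in either direction, so that a number 3.3 percentage points lower from compound 3 to compound 4 (within the scatter) is the expected change. The estimate for compound 4 is 66%, within a range from 50% to 80%.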

Compound 4, a percentage reported as inhibition, in the whole organism at one dose (the size of the read-out at that dose, not a potency): 53.3%
The estimate for compound 4 lay 12.7 percentage points above the measured number; measured number inside the range.
By their numbers in this assay, from the lowest: compounds 2, 4, 1 and 3 (each within the scatter of the next, the first and the last beyond it).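

In this assay, among these compounds, adding a methoxy to the ring gave a number 16 percentage points lower from compound 3 to compound 4 (beyond the scatter), and this is the first step in which a group takes the place of a hydrogen rather than of another group. The earlier steps shown here showed only how the read-out responds to exchanges at one aromatic carbon, whereas this step shows that it also responds at a second carbon of that ring, ortho to a methoxy group and meta to a large group, when only 2 heavy atoms enter. Nothing available accounts for this drop, so the compounds show its size but not its cause.

On these data alone, it remains open whether any group at this carbon would lower the number, or whether the result is specific to methoxy, as a fluorine, a hydroxyl or an ethoxy there could show. As far as these compounds go, it is also open whether the drop depends on the neighbouring methoxy, which could be tested by pairing the new methoxy with the chloro of compound 1.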